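This account rests on a few compounds, and the source may have more. Where it says the series, first, only, none or still open, it means among the compounds named here.

Measured so far, in a functional assay on MDA-MB-231 cells (Homo sapiens) for cytotoxicity, read by MTT assay; a lower number here means a stronger inhibitor, a higher number a weaker inhibitor:
compound 1, `CCn1cc(C(=O)Nc2ccccc2)c(=O)c2cc(F)c(N3CCNC(C)C3)c(F)c21`, gives 7400 nM
compound 2, `CCn1cc(C(=O)Nc2ccccc2N)c(=O)c2cc(F)c(N3CCNC(C)C3)c(F)c21`, gives 9500 nM
compound 3, `CCn1cc(C(=O)Nc2cccc([N+](=O)[O-])c2)c(=O)c2cc(F)c(N3CCNC(C)C3)c(F)c21`, gives 3250 nM

Compound 3 stands lowest of the three numbers in this assay: the step of a 2.3-fold lower number from compound 1 to compound 3 (0.36 log units; beyond the scatter) and the step of a 2.9-fold lower number from compound 2 to compound 3 (0.47 log units; beyond the scatter) both lie beyond the scatter. Compound 4, `CCn1cc(C(=O)Nc2cc([N+](=O)[O-])ccc2F)c(=O)c2cc(F)c(N3CCNC(C)C3)c(F)c21`, is the next compound in line; it has not yet been measured. The change from compound 3 to compound 4 is fluoro in place of hydrogen on an aromatic carbon, a fluoro in place of hydrogen on an aromatic carbon, ortho to a large group and para to a nitro group.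

For the measured compounds named here, no measured step adds a fluoro on this ring, so the closest evidence is how other substituents on the same ring have behaved. Adding a nitro moved the number by a 2.3-fold lower number from compound 1 to compound 3 (0.36 log units; beyond the scatter), a modest step; adding an amino gave a 1.3-fold higher number from compound 1 to compound 2 (0.11 log units; within the scatter), which stays within the scatter. On that basis, a small substituent of one heavy atom is expected to shift compound 4 little, and the expected step of a 1.1-fold lower number from compound 3 to compound 4 (0.03 log units; within the scatter) is held within the scatter. Compound 4 is therefore estimated at 3000 nM in this assay, with a range from 1200 nM to 7500 nM.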

Compound 4, half-maximal inhibitory concentration: 6900 nM
The estimate for compound 4 lay 2.3-fold (0.36 log units) below the measured number; the measured number falls inside the stated range.
By their numbers in this assay, from the lowest: compound 3; then compounds 4, 1 and 2 (each within the scatter of the next).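

In this assay, a single fluoro, ortho to a large group and para to a nitro group, gives a 2.1-fold higher number from compound 3 to compound 4 (0.33 log units; beyond the scatter): this is the first fluoro on this ring among the compounds shown, and this one-atom change moves the number beyond the scatter. Its direction is opposite to that of the step on adding the nitro group (a 2.3-fold lower number from compound 1 to compound 3 (0.36 log units; beyond the scatter)), and the 2-fluoro-5-nitrophenyl compound stands within the scatter of both the phenyl compound (a 1.1-fold lower number from compound 1 to compound 4 (0.03 log units; within the scatter)) and the 2-aminophenyl compound (a 1.4-fold lower number from compound 2 to compound 4 (0.14 log units; within the scatter)), so on this ring the fluoro cancels the gain that the nitro group alone gave. No measurement at hand bears on what lies behind this shift, so it stays a bare observation.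

The compounds shown leave open whether the fluoro would move the number in the same way on a ring that carries no nitro group, as in a 2-fluorophenyl amide. They also leave open whether a chloro, a methyl or a methoxy group in place of the fluoro would give a similar step, or whether the step is particular to fluoro.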